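The source may report more compounds than this note shows. Statements on the series, on what has been measured and on what is new or still open speak of the compounds shown alone.

Three compounds share a core in which a pyridine ring is attached to a fused bicyclic system. Compound 1 `Cn1c(-c2cccnc2)nc2ccc(F)cc21` carries a methyl group and one fluoro; compound 2 `Fc1cc2nc(-c3cccnc3)n(C3CC3)c2cc1F` carries a cyclopropyl group and two fluoro atoms; compound 3 `c1cncc(-c2nc3ccccc3n2C2CC2)c1` carries a cyclopropyl group and no fluoro. In an assay on V79 cells for inhibition of cytochrome P450 11B2, mitochondrial (Homo sapiens), read by HTRF, with a stated time of 1 h (on this read-out higher numbers stand for weaker inhibition and lower numbers for stronger inhibition), compound 1 gives 12 nM, compound 2 gives 2.1 nM, and compound 3 gives 49 nM, the highest of the three numbers and so the weakest inhibitor here, with both gaps beyond the scatter.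

Compound 4 `Fc1ccc2nc(-c3cccnc3)n(C3CC3)c2c1` is compound 3 with one change: fluoro in place of hydrogen on an aromatic carbon. Compound 1 and compound 2, the two fluoro-bearing compounds, both give lower numbers than compound 3, although each differs from it in more than one place, so no single step can be read off. On that basis compound 4 is expected to inhibit more strongly than compound 3. The step expected here is a 5.4-fold lower number from compound 3 to compound 4 (0.74 log units; beyond the scatter). Compound 4 is estimated at 9 nM, within a range from 3 nM to 27 nM.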

Compound 4, half-maximal inhibitory concentration: 4 nM
Compound 4: middle estimate off by 2.3-fold (0.35 log units), on the high side; low and high end bracket the measured number.
By their numbers in this assay, from the lowest: compounds 2 and 4 (each within the scatter of the next); then compound 1; then compound 3.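

For the compounds shown here, compound 3 and compound 4 differ only by a fluoro on an aromatic carbon of the six-membered ring of carbon only, and in this assay that single atom gives a 12-fold lower number from compound 3 to compound 4 (1.09 log units; beyond the scatter), a large step that the earlier compounds, each differing in more than one place, could not isolate. With hydrogen in place of the other fluoro, the step is a 1.9-fold higher number from compound 2 to compound 4 (0.28 log units; within the scatter), so this second fluoro has no effect that can be told apart from the scatter. Cyclopropyl in place of methyl on the aromatic nitrogen, with the fluoro kept, gives a 3.0-fold lower number from compound 1 to compound 4 (0.48 log units; beyond the scatter), a modest step.

Nothing shown gives a cause for any of these steps. From the compounds shown here alone, whether chloro, methoxy or an amine on the same carbon would match fluoro remains open.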